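A Chlorine Shift in a Weak Growth Inhibitor

This account rests on a few compounds, and the source may have more. Where it says the series, first, only, none or still open, it means among the compounds named here.

In a functional assay on SW-620 cells (Homo sapiens) (a higher number here means a weaker inhibitor of growth, a lower number a stronger inhibitor of growth), compound 1 (`N#Cc1ccc(/C=C/S(=O)(=O)Cc2ccc(Nc3ncnc4ccccc34)cc2)cc1`) gives > 100000 nM as a limit of the assay, not a number. Going by the values given here, compound 2 (`O=S(=O)(/C=C/c1ccc(Cl)c(Cl)c1)Cc1ccc(Nc2ncnc3ccccc23)cc1`) gives 41000 nM as the only actual number so far. Among the compounds with values here, the one measured step, an at least 2.4-fold lower number from compound 1 to compound 2 (0.38 log units; beyond the scatter) on exchanging 4-cyanophenyl for 3,4-dichlorophenyl, starts from the limit of > 100000 nM in this assay, at which 1 of the 2 values shown sits, and so gives only a bound. In compound 3 (`O=S(=O)(/C=C/c1ccc(Cl)cc1Cl)Cc1ccc(Nc2ncnc3ccccc23)cc1`) 2,4-dichlorophenyl stands in place of 3,4-dichlorophenyl, the same atoms joined differently, as 2,4-dichlorophenyl in place of 3,4-dichlorophenyl on a double-bonded chain carbon bound to a double-bonded chain carbon sets out in full. Within the data shown here, no measured step compares these two groups, so no step beyond the scatter is expected in this assay and no direction is favoured. The expectation leans on compound 2 at 41000 nM as the closest measured neighbour. The expected change is a 1.1-fold higher number from compound 2 to compound 3 (0.04 log units; within the scatter) on this reasoning. Compound 3 is estimated at 45000 nM with an expected range of 18000 nM to 100000 nM in this assay.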

Compound 3, concentration for 50% growth inhibition: 14000 nM
For compound 3 the middle estimate is 3.2-fold (0.51 log units) above the measured one, outside the stated range (below it).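

In this assay, the arrangement of the two chlorines on the phenyl ring matters, not only their presence: with the same atoms joined differently, 2,4-dichlorophenyl in place of 3,4-dichlorophenyl gives a 2.9-fold lower number from compound 2 to compound 3 (0.47 log units; beyond the scatter). Exchanging 4-cyanophenyl for 2,4-dichlorophenyl at this position on the double-bonded chain carbon gives an at least 7.1-fold lower number from compound 1 to compound 3 (0.85 log units; beyond the scatter). That step fixes only a minimum size, because compound 1 stands at a limit of the assay and not at a number: the limit of > 100000 nM in this assay, at which 1 of the 3 values shown sits.

On these data alone, what a single chlorine would give here, as in 2-chlorophenyl or 4-chlorophenyl, remains open, so the step cannot yet be assigned to either chlorine. Also open, as far as these compounds go, is whether the arrangement in 2,4-dichlorophenyl holds with other atoms, as in 2,4-difluorophenyl or 2,4-dimethoxyphenyl.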